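The compounds below may be only part of what the source reports. "The series", "measured", "known", "first", "only" and "open" are said of these compounds alone.

Measured so far in an assay on HEK293 cells for inhibition of Voltage-dependent T-type calcium channel subunit alpha-1G (Homo sapiens), read by patch clamp; a lower number here means a stronger inhibitor, a higher number a weaker inhibitor:
- compound 1 `CCCc1nc(-c2ccccc2)c(CNCCCN2CCN(c3ccc(F)cc3)CC2)o1` gives 3210 nM
- compound 2 `CCCc1nc(-c2ccccc2)c(CNCCN2CCN(c3ccccc3C)CC2)o1` gives 4300 nM
- compound 3 `CCCc1nc(-c2ccccc2)c(CNCCN2CCN(c3ccccc3)CC2)o1` gives 10300 nM

Compound 1 carries the lowest of the three numbers in this assay. Its gap to compound 2 falls within the usual scatter, so the two are not separated; its gap to compound 3 lies beyond the scatter. For the measured compounds named here, the only single-point step among the measured set, a 2.4-fold higher number from compound 2 to compound 3 (0.38 log units; beyond the scatter), is the loss of the methyl on the aryl ring of the piperazine, and it raises the number modestly.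

The unmeasured compound 4 `CCCc1nc(-c2ccccc2)c(CNCCCN2CCN(c3ccc(C)c(C)c3)CC2)o1` is reached from compound 1 by one change: 3,4-dimethylphenyl in place of 4-fluorophenyl on an amine nitrogen in a ring. Going by the values given here, no measured pair exchanges a fluorine for hydrogen on that ring, so that part of the change has no direct precedent. The part that adds methyl groups to the aryl ring is mirrored, in reverse, by the step from compound 2 to compound 3, where a methyl on the aryl ring goes with a lower number. On that basis a modest drop in the number, or none beyond the scatter, is expected for compound 4, as a 1.8-fold lower number from compound 1 to compound 4 (0.25 log units; within the scatter).

Compound 4 is therefore estimated at 1800 nM in this assay, with an expected range from 700 nM to 5000 nM.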

Compound 4, half-maximal inhibitory concentration: 3020 nM
Compound 4: middle estimate off by 1.7-fold (0.22 log units), on the low side; the measured number falls inside the stated range.
By their numbers in this assay, from the lowest: compounds 4, 1 and 2 (each within the scatter of the next); then compound 3.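

In this assay, the exchange of 4-fluorophenyl for 3,4-dimethylphenyl on an amine nitrogen in a ring gives a 1.1-fold lower number from compound 1 to compound 4 (0.03 log units; within the scatter), so with the chain of compound 1 these two aryl groups are not separated. The methyl step seen earlier, a 2.4-fold higher number from compound 2 to compound 3 (0.38 log units; beyond the scatter), therefore does not extend to this pair as a general rule: here, methyl groups enter and the fluorine leaves without a change beyond the scatter, although the two methyl groups and the loss of the fluorine cannot be read apart in this single step. No available evidence bears on why the two aryl groups read alike.

The compounds shown leave open how a plain phenyl, a 4-methylphenyl or a 4-methoxyphenyl on this nitrogen would read with the chain of compound 1, which would help to separate the part played by the fluorine from that of the methyl groups. Also open are the effect of the chain alone, since no pair shown differs only there, and the reading of an aryl ring carrying a carboxylic acid or an amine.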